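This account rests on a few compounds, and the source may have more. Where it says the series, first, only, none or still open, it means among the compounds named here.

Compound 1 `O=C1/C(=C/c2cccc(F)c2)Cc2cc(O)ccc21` was tested in an assay on isolated protein for inhibition of Amine oxidase [flavin-containing] B (Homo sapiens), read by fluorescence and spectrophotometry, with a stated time of 20 min (on this read-out higher numbers stand for weaker inhibition and lower numbers for stronger inhibition), where compound 1 gives 84 nM. Among the three measured compounds it stands second highest: compound 2 `O=C1/C(=C/c2ccc(F)cc2)Cc2cc(O)ccc21` gives 47 nM, which lies within the scatter of compound 1, while compound 3 `N#Cc1ccc(/C=C2\Cc3cc(O)ccc3C2=O)cc1` gives 316 nM, a higher number than compound 1 by more than the scatter. Compound 4 `O=C1/C(=C/c2cccc(O)c2)Cc2cc(O)ccc21` differs from compound 1 by hydroxy in place of fluoro on an aromatic carbon. Going by the values given here, the only measured step that bears on a swap of the fluoro on that ring is a 6.7-fold higher number from compound 2 to compound 3 (0.83 log units; beyond the scatter), a replacement by another small polar group at a different place. A comparable but weaker effect is therefore expected, namely a 1.9-fold higher number from compound 1 to compound 4 (0.28 log units; within the scatter). Compound 4 is estimated at 160 nM, in the range 55 nM to 500 nM.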

Compound 4, half-maximal inhibitory concentration: 966 nM
Compound 4: the middle estimate sits 6.0-fold (0.78 log units) below what was measured; measured number outside the range, above it.
By their numbers in this assay, from the lowest: compounds 2 and 1 (each within the scatter of the next); then compound 3; then compound 4.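

In this assay, hydroxy in place of fluoro on this aromatic carbon gives a 12-fold higher number from compound 1 to compound 4 (1.06 log units; beyond the scatter), the first step shown at this position, so here the fluoro cannot be exchanged for hydroxy without a large loss of inhibition. No measurement at hand offers a reason for this step.

From the compounds shown here alone, whether an amine or a methoxy at this place would cost as much as hydroxy remains open. So does whether hydroxy in place of the fluoro of compound 2 would produce a step of similar size.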